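A Vinyl for a Cyclopropyl on the Nitrogen-Bound Chain

A few compounds are considered here, and "the series" means these few. Any claim that something is new, unique, unknown or untested is made for them only; others in the source may bear on it.

Measured compounds:
compound 1 `CCCc1nc(C)c2cnn(CC3CC3)c(=O)n12`, > 48000 nM in a functional assay for inhibition, with Homo sapiens as the target; on this read-out higher numbers stand for weaker inhibition and lower numbers for stronger inhibition
compound 2 `CCOC(=O)CSc1nncc2cnc(C)n12`, 52000 nM in this assay

In this assay compound 1 gives > 48000 nM, which is a limit of the assay and not a number. Compound 2 gives 52000 nM in this assay. Among the measured compounds shown here, no step between these two is counted, so only their two values stand side by side, and neither shows strong inhibition. Compound 3 `C=CCn1ncc2c(C)nc(CCC)n2c1=O` is not yet measured. It differs from compound 1 by vinyl in place of cyclopropyl on a saturated chain carbon bound to an aromatic nitrogen. For the measured compounds named here, because compound 1 sits at the limit of > 48000 nM in this assay, at which 1 of the 2 values shown sits, there is no measured step to lean on, and the change is a small one on a saturated chain carbon bound to an aromatic nitrogen. The step from compound 1 to compound 3 is expected to be a step that the limit leaves unreadable from compound 1 to compound 3, nothing beyond the scatter in either direction. Compound 3 is therefore expected to give about 50000 nM in this assay, within 20000 nM to 150000 nM, with a fair chance that only a limit is reported again.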

Compound 3, half-maximal inhibitory concentration: 40000 nM
Estimate against measurement, compound 3: 1.3-fold (0.10 log units) above; the range from low to high includes it.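

In this assay, vinyl in place of cyclopropyl on the saturated chain carbon bound to an aromatic nitrogen gives an at least 1.2-fold lower number from compound 1 to compound 3 (0.07 log units; that floor lies within the scatter), so this place now carries a readable number, with compound 3 at 40000 nM. Compound 1 stays at > 48000 nM, which is a limit of the assay and not a number. The true size of the step therefore cannot be read, and the change shows only a floor that does not clear the scatter, because one end of the step is a limit: the limit of > 48000 nM in this assay, at which 1 of the 3 values shown sits.

The compounds shown leave open whether a longer chain, an amine or a carboxylic acid at this place would bring the number down any further. They also leave open whether any group here reaches strong inhibition.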